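Vinyl for iodo on the selenium-containing core

The compounds below may be only part of what the source reports. "The series", "measured", "known", "first", "only" and "open" are said of these compounds alone.

Compound 1 `C#Cc1nc2ccccc2n1C` — 19400 nM
Compound 2 `Ic1nc2ccccc2[se]1` — > 40000 nM
Compound 3 `Cn1c(I)nc2ccccc21` — 17500 nM

Among the compounds with values here, in a functional assay on HCT-116 cells (Homo sapiens) for cytotoxicity, with a stated time of 3 days (a higher number here means a weaker inhibitor, a lower number a stronger inhibitor), compound 2 reaches only a limit of the assay, > 40000 nM, so its place among the numbers is not fixed; it is the one compound (the limit of > 40000 nM in this assay, at which 1 of the 3 values shown sits). Compound 4 `C=Cc1nc2ccccc2[se]1` differs from compound 2 by vinyl in place of iodo on an aromatic carbon. Within the data shown here, the only measured step that bears on it is the exchange of an iodo for an ethynyl group on the related core, a 1.1-fold lower number from compound 1 to compound 3 (0.04 log units; within the scatter), which shows no difference beyond the scatter between those two groups. For compound 4 the estimate is therefore a step that the limit leaves unreadable from compound 2 to compound 4, that is no clear change, and compound 4 is expected near 45000 nM, within 15000 nM to 120000 nM.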

Compound 4, half-maximal inhibitory concentration: > 40000 nM
Compound 4 ended at the assay's limit (the forecaster's own chance of this, stated with the estimate: 60%); the middle value is on the limit's open side.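

In this assay compound 2 and compound 4 both stand at a limit of the assay, so no step between them can be read: the limit of > 40000 nM in this assay, at which 2 of the 4 values shown sit.

As far as these compounds go, whether vinyl and iodo on this shared core differ at all in this assay stays open.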